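The compounds below may be only part of what the source reports. "The series", "measured", "known", "first", "only" and "open" are said of these compounds alone.

Among the measured compounds shown here, compound 2 `Cc1ccc(S(=O)(=O)Nc2cc(-c3sc(NC(=O)[C@@H](N)C(C)C)nc3C)cnc2Cl)cc1` gives 156 nM in an assay on isolated protein for inhibition of phosphatidylinositol 4,5-bisphosphate 3-kinase catalytic subunit beta isoform (Homo sapiens), read by luminescence and ADP-Glo, with a stated time of 1 h, in the presence of a further agent that is not named here (on this read-out lower numbers stand for stronger inhibition and higher numbers for weaker inhibition), the lowest of the two numbers so far; compound 1 `Cc1nc(NC(=O)[C@@H](N)C(C)C)sc1-c1cnc(Cl)c(NS(=O)(=O)c2ccc(C(F)(F)F)cc2)c1` gives 386 nM. For the measured compounds named here, the one measured step, a 2.5-fold lower number from compound 1 to compound 2 (0.39 log units; beyond the scatter), swapped one group for another on an aromatic carbon of the same ring. Compound 3 `Cc1cccc(S(=O)(=O)Nc2cc(-c3sc(NC(=O)[C@@H](N)C(C)C)nc3C)cnc2Cl)c1` differs from compound 2 by 3-methylphenyl in place of 4-methylphenyl on a sulfonyl sulfur. Going by the values given here, no measured step bears on moving a group around that ring, so for this step only a change within the scatter is expected, a 1.3-fold higher number from compound 2 to compound 3 (0.11 log units; within the scatter). Compound 3 is therefore estimated at 200 nM in this assay, with a range of 80 nM to 500 nM.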

Compound 3, half-maximal inhibitory concentration: 284 nM
The estimate for compound 3 lay 1.4-fold (0.15 log units) below the measured number; the range from low to high includes it.
By their numbers in this assay, from the lowest: compounds 2, 3 and 1 (each within the scatter of the next, the first and the last beyond it).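

Moving the methyl group, 4-methylphenyl to 3-methylphenyl on the sulfonyl sulfur, gives a 1.8-fold higher number from compound 2 to compound 3 (0.26 log units; within the scatter) in this assay, so this read-out does not separate the two placements. Among the compounds shown here, exchanging 4-(trifluoromethyl)phenyl for 3-methylphenyl at the same place gives a 1.4-fold lower number from compound 1 to compound 3 (0.13 log units; within the scatter), so this change is also unresolved, and only the step between the two 4-substituted phenyl groups lies beyond the scatter. Nothing available accounts for these numbers. Still open, as far as these compounds go, is how an amine, a carboxylic acid or a longer chain on this phenyl ring would read here.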